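This account rests on a few compounds, and the source may have more. Where it says the series, first, only, none or still open, it means among the compounds named here.

Three compounds share one core and differ only in the group attached to the carbonyl carbon. Compound 1 `CCc1ccccc1C(=O)OC(CCN(C)C)c1ccc(Cl)cc1` gives 1290 nM in an assay on NIH3T3 cells with Urotensin-2 receptor (Homo sapiens) as the target; a higher number here means that more compound is needed for the effect, a lower number that less compound is needed. Compound 2 `Cc1ccc(C(=O)OC(CCN(C)C)c2ccc(Cl)cc2)cc1` gives 2750 nM in this assay, and compound 3 `Cc1ccccc1NC(=O)OC(CCN(C)C)c1ccc(Cl)cc1` gives 3890 nM in this assay, the highest of the three numbers. One step is a 3.0-fold higher number from compound 1 to compound 3 (0.48 log units; beyond the scatter), whereas a 1.4-fold higher number from compound 2 to compound 3 (0.15 log units; within the scatter) stays within the scatter. Compound 4 `CN(C)CCC(OC(=O)NCc1ccccc1)c1ccc(Cl)cc1` carries benzyl in place of 2-methylphenyl on an amide-type nitrogen. For the measured compounds named here, no measured step makes this kind of change on the nitrogen, and the only step that touches that nitrogen stays within the scatter, so no shift beyond the scatter is expected, a 1.0-fold higher number from compound 3 to compound 4 (0.01 log units; within the scatter). Compound 4 is therefore estimated at 4000 nM in this assay, with a range from 1500 nM to 11000 nM.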

Compound 4, half-maximal effective concentration: 2140 nM
Beside the measured number, compound 4's estimate is 1.9-fold (0.27 log units) above it; low and high end bracket the measured number.
By their numbers in this assay, from the lowest: compounds 1, 4, 2 and 3 (each within the scatter of the next, the first and the last beyond it).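

In this assay, benzyl on the amide-type nitrogen in place of 2-methylphenyl gives a 1.8-fold lower number from compound 3 to compound 4 (0.26 log units; within the scatter) and so shows no clear change at this position. Compound 4 also stays close to the two compounds with an aryl group on the carbonyl carbon, with a 1.3-fold lower number from compound 2 to compound 4 (0.11 log units; within the scatter) and a 1.7-fold higher number from compound 1 to compound 4 (0.22 log units; within the scatter) even though compound 1 and compound 3 are separated beyond the scatter. No supporting evidence is available to explain these small steps. From the compounds shown here alone, whether 2-phenylethyl on that nitrogen, or methyl in place of the amide hydrogen, would move the number beyond the scatter stays open.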